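Compound 3 to compound 4: furan-2-yl gives thiophen-3-yl

The compounds below may be only part of what the source reports. "The series", "measured", "known", "first", "only" and "open" are said of these compounds alone.

Measured so far in a functional assay on MDA-MB-468 cells (Homo sapiens) for inhibition, read by CCK-8 assay and cell counting, with a stated time of 2 days; a higher number here means a weaker inhibitor, a lower number a stronger inhibitor
compound 1 `O=C(/C=C/c1ccco1)c1ccccc1OCC1CO1` gives 48300 nM
compound 2 `O=C(/C=C/c1ccco1)c1cccc(OCC2CO2)c1` gives 37300 nM
compound 3 `O=C(/C=C/c1ccco1)c1ccc(OCC2CO2)cc1` gives 48900 nM

The three measured compounds share the furan-2-yl group and differ only in the placement of one substituent on the shared core. In this assay compound 3 at 48900 nM lies within the scatter of both other compounds, so it cannot be separated from either of them on these numbers.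

The next compound is compound 4 `O=C(/C=C/c1ccsc1)c1ccc(OCC2CO2)cc1` and it has not yet been measured. It differs from compound 3 as follows: thiophen-3-yl in place of furan-2-yl on a double-bonded chain carbon bound to a double-bonded chain carbon with thiophen-3-yl in place of furan-2-yl on a double-bonded chain carbon bound to a double-bonded chain carbon.

Going by the values given here, no measured pair shows this exchange, so the data give no direct guide to its size. The only reference is the narrow spread of the measured values, with compound 2 at 37300 nM and compound 3 at 48900 nM in the same range. The expected change, a 1.3-fold lower number from compound 3 to compound 4 (0.11 log units; within the scatter), is estimated to stay within the scatter in this assay with no firm direction. For compound 4 the estimated value is 38000 nM with an expected range from 15000 nM to 85000 nM in the same test.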

Compound 4, half-maximal inhibitory concentration: 10800 nM
For compound 4 the middle estimate is 3.5-fold (0.55 log units) above the measured one; the measured number lies below the stated range.
By their numbers in this assay, from the lowest: compound 4; then compounds 2, 1 and 3 (each within the scatter of the next).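

In this assay the exchange of furan-2-yl for thiophen-3-yl on a double-bonded chain carbon bound to a double-bonded chain carbon gives a 4.5-fold lower number from compound 3 to compound 4 (0.66 log units; beyond the scatter), the first separation in the series beyond the scatter, whereas the different placements of one substituent on the shared core in compound 1, compound 2 and compound 3 separated nothing. This chain position therefore responds to the identity of the five-membered aromatic ring, although both groups have the same counts of heavy atoms, hydrogen-bond donors and hydrogen-bond acceptors and carry no net charge, with sulfur in place of oxygen and a different ring attachment as the visible differences. No measurement available here bears on the origin of this step, which rests on one pair of compounds.

Open, as far as these compounds go, is whether thiophen-3-yl gives a similar step with the substituent placed as in compound 1 or compound 2, and whether thiophen-2-yl or furan-3-yl would separate the hetero atom from the point of attachment. Also open, from the compounds shown here alone, is whether a phenyl or pyridin-3-yl ring at the same chain carbon would retain the lower number.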